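Aryl swap on a stilbene-bearing indole, cytotoxicity

A few compounds are considered here, and "the series" means these few. Any claim that something is new, unique, unknown or untested is made for them only; others in the source may bear on it.

Measured so far:
compound 1, `CC(=O)c1cc(/C=C/c2ccc(F)cc2)cc2cc(-c3ccccc3)[nH]c12`, 32.8%
compound 2, `CC(=O)c1cc(/C=C/c2ccc(F)cc2)cc2cc(-c3ccc(F)cc3)[nH]c12`, 41.9%

Both compounds were tested in a functional assay on HeLa cells (Homo sapiens) for cytotoxicity, read by MTT assay, with a stated time of 2 days, tested at 10 uM; a higher number here means a weaker effect of the compound at the concentration tested, a lower number a stronger effect. Compound 2 gives the higher of the two numbers, but the step of a number 9.1 percentage points higher from compound 1 to compound 2 (within the scatter) lies within the scatter, so the two results cannot be told apart. Compound 3, `COc1ccc(-c2cc3cc(/C=C/c4ccc(F)cc4)cc(C(C)=O)c3[nH]2)cc1`, has not yet been measured. It differs from compound 2 in one place: methoxy in place of fluoro on an aromatic carbon. For the measured compounds named here, no measured pair shows this change; the only step available, from fluoro in place of hydrogen, was small and does not match it. The data therefore give no ground for expecting a step beyond the scatter. Compound 3 is estimated to give 42% in this assay, with a range from 24% to 62%. This estimate corresponds to a step of a number 0.1 percentage points higher from compound 2 to compound 3 (within the scatter), which is an expectation of no change beyond the scatter.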

Compound 3, a percentage reported as activity, at one concentration (the size of the read-out at that concentration, not a potency): 25.8%
Beside the measured number, compound 3's estimate is 16.2 percentage points above it; the measured number falls inside the stated range.
By their numbers in this assay, from the lowest: compounds 3, 1 and 2 (each within the scatter of the next, the first and the last beyond it).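

In this assay the change from 4-fluorophenyl to 4-methoxyphenyl comes with a number 16.1 percentage points lower from compound 2 to compound 3 (beyond the scatter) and so shows what the step from hydrogen to fluoro did not: a substituent at this aromatic carbon, para to a large group, can shift the read-out beyond the scatter. Set against hydrogen at the same carbon, methoxy gives a number 7 percentage points lower from compound 1 to compound 3 (within the scatter) and cannot be told apart from it, so the one clear gap lies only between the fluoro and methoxy compounds. Nothing available bears on the reason for this gap.

From the compounds shown here alone, whether the gap belongs to methoxy alone remains open. An amine, a carboxylic acid or a longer chain such as butoxy at this carbon would show whether other groups also separate from fluoro.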